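Moving the Methyl on the Phenoxy Ring

The source may report more compounds than this note shows. Statements on the series, on what has been measured and on what is new or still open speak of the compounds shown alone.

Among the measured compounds shown here, compound 2 `Cc1ccccc1Oc1cccc(COc2ccccc2CCC(=O)OCCCOP(=O)(O)OC[C@H](N)C(=O)O)c1` is one of two compounds measured so far in an assay on cells for agonist activity at probable G-protein coupled receptor 34 (Mus musculus), with a stated time of 1 h (a higher number here means a larger maximal response, a lower number a smaller maximal response), and the two lie within the scatter of each other. In this assay compound 2 gives 20.3%. Compound 1 `N[C@@H](COP(=O)(O)OCCCOC(=O)CCc1ccccc1OCc1cccc(Oc2ccccc2)c1)C(=O)O` carries hydrogen where compound 2 carries methyl on an aromatic carbon, and in this assay compound 1 gives 19.4%; the step of a number 0.9 percentage points higher from compound 1 to compound 2 (within the scatter) shows that the methyl made no difference beyond the scatter.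

Compound 3 `Cc1ccc(Oc2cccc(COc3ccccc3CCC(=O)OCCCOP(=O)(O)OC[C@H](N)C(=O)O)c2)cc1` has not yet been measured in this assay. It differs from compound 2 as follows: 4-methylphenyl in place of 2-methylphenyl on an oxygen on an aromatic ring. For the measured compounds named here, only one measured step bears on this change, namely a number 0.9 percentage points higher from compound 1 to compound 2 (within the scatter), which concerns the same methyl group and stayed within the scatter. Going by the values given here, no measured pair shows the 4-methylphenyl itself. Because a number 0.9 percentage points higher from compound 1 to compound 2 (within the scatter) lay within the scatter, the account expects the relocation of the methyl to leave the response unchanged as well, with no step beyond the scatter in this assay. The expected step is a number 0.3 percentage points lower from compound 2 to compound 3 (within the scatter). Compound 3 is therefore estimated at 20%, in a range from 10% to 32%.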

Compound 3, largest response reached (Emax), in percent of the reference or control that the assay uses: 18.2%
Beside the measured number, compound 3's estimate is 1.8 percentage points above it; low and high end bracket the measured number.
By their numbers in this assay, from the lowest: compounds 3, 1 and 2 (each within the scatter of the next).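

Moving the methyl from 2-methylphenoxy to 4-methylphenoxy gives a number 2.1 percentage points lower from compound 2 to compound 3 (within the scatter) in this assay, so the place of the methyl on this ring, and not only its presence, has now been tested, and this change also stays inside the scatter. Methyl in place of hydrogen on an aromatic carbon gives a number 1.2 percentage points lower from compound 1 to compound 3 (within the scatter), which means that this replacement has now been read at two places on the ring, with neither step beyond the scatter. Within this small set, neither adding the methyl nor moving it separates the compounds by their largest response, and no measurement shown offers a reason for this result.

What the compounds leave open is whether a different group on this ring, such as a chlorine, a methoxy or an amine, would produce a step beyond the scatter, or whether the ring tolerates such groups as it does the methyl. Also open, from the compounds shown here alone, is whether a change elsewhere in the molecule, such as an amide in place of the ester or a longer chain, would alter the response in this assay.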